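Working notes: one added hydroxy on compound 2

A few compounds are considered here, and "the series" means these few. Any claim that something is new, unique, unknown or untested is made for them only; others in the source may bear on it.

- compound 1 `COC(=O)c1c(-c2ccc(O)cc2)oc2ccc(OC)cc2c1=O`: > 25 ug/mL
- compound 2 `O=c1cc(-c2ccc([N+](=O)[O-])cc2)oc2cc(O)ccc12`: > 25 ug/mL

Both entries come from a functional assay on Malme-3M cells (Homo sapiens) for cytotoxicity, read by MTT assay, with a stated time of 6 days; a higher number here means that more compound is needed for the effect, a lower number that less compound is needed. Compound 2 stands at > 25 ug/mL, which is a limit and not a number. For the measured compounds named here, the series so far shows only (the limit of > 25 ug/mL in this assay, at which 2 of the 2 values shown sit).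

Compound 3 `O=c1cc(-c2ccc([N+](=O)[O-])cc2)oc2c(O)c(O)ccc12` has hydroxy in place of hydrogen on an aromatic carbon, ortho to a hydroxy group (hydroxy in place of hydrogen on an aromatic carbon). Going by the values given here, no measured step is available as a guide. A small move toward less compound needed is expected, estimated as an at least 1.2-fold lower number from compound 2 to compound 3 (0.09 log units; that floor lies within the scatter). Compound 3 is expected at 20 ug/mL, with an estimated range of 7 ug/mL to 50 ug/mL. Another result reported only as a limit remains likely.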

Compound 3, concentration for half-maximal effect: 3.61 ug/mL
Compound 3: the middle estimate sits 5.5-fold (0.74 log units) above what was measured; the whole stated range lies above it.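

In this assay, hydroxy in place of hydrogen on an aromatic carbon, ortho to a hydroxy group, produces a step beyond the scatter (an at least 6.9-fold lower number from compound 2 to compound 3 (0.84 log units; beyond the scatter)), so this position responds to one added hydroxy. On these data alone, compound 2 stands at > 25 ug/mL as a limit of the assay, so the true size of the step stays unknown. For the compounds shown here, compound 3 is the only one of the three compounds off that limit: (the limit of > 25 ug/mL in this assay, at which 2 of the 3 values shown sit).

As far as these compounds go, whether an amine or a carboxylic acid at this position would give a similar step remains open. Also open, from the compounds shown here alone, is whether hydroxy here needs the existing hydroxy group.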